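This account rests on a few compounds, and the source may have more. Where it says the series, first, only, none or still open, it means among the compounds named here.

Compound 1 `CCCNC(=C\C(=O)/C=C/c1ccc(O)c(OC)c1)/C=C/c1ccc(O)c(OC)c1` – 141%
Compound 2 `COc1cc(/C=C/C(=O)/C=C(/C=C/c2ccc(O)c(OC)c2)NC2CCCCC2)ccc1O` – 191%
Compound 3 `COc1cc(/C=C/C(=O)/C=C(/C=C/c2ccc(O)c(OC)c2)NCC(C)C)ccc1O` – 100%

In a functional assay on EA.hy 926 cells (Homo sapiens), read by fluorescence, tested at 10 uM (on this read-out higher numbers stand for a stronger effect at the one concentration tested and lower numbers for a weaker effect), compound 3 stands lowest of the three: compound 1 is a number 41 percentage points lower from compound 1 to compound 3 (beyond the scatter) turned around, and compound 2 lies further off, as a number 91 percentage points lower from compound 2 to compound 3 (beyond the scatter) shows. Compound 4 `CCCCNC(=C\C(=O)/C=C/c1ccc(O)c(OC)c1)/C=C/c1ccc(O)c(OC)c1` differs from compound 3 by propyl in place of isopropyl on a saturated chain carbon bound to an amine nitrogen, that is, isobutyl becoming butyl on the amine nitrogen. The step that bears most directly on this is a number 41 percentage points lower from compound 1 to compound 3 (beyond the scatter), where a branch on the chain went with a large fall; compound 4 undoes that branch and keeps the straight chain only one carbon longer than in compound 1. A rise in this assay of roughly that size is therefore expected, a number 35 percentage points higher from compound 3 to compound 4 (beyond the scatter). Compound 4 is estimated at 135%, within 95% to 175%.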

Compound 4, a percentage reported as activity, at one concentration (the size of the read-out at that concentration, not a potency): 439%
Beside the measured number, compound 4's estimate is 304 percentage points below it, outside the stated range (above it).
By their numbers in this assay, from the lowest: compound 3; then compound 1; then compound 2; then compound 4.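

In this assay, going by these compounds alone, the group on the amine nitrogen proves far more sensitive than the earlier compounds showed: the same atoms joined differently, isobutyl becoming butyl, give a very large rise (a number 339 percentage points higher from compound 3 to compound 4 (beyond the scatter)). Lengthening propyl to butyl also gives far more than any earlier change (a number 298 percentage points higher from compound 1 to compound 4 (beyond the scatter)), and the butyl chain surpasses the cyclohexyl ring as well (a number 248 percentage points higher from compound 2 to compound 4 (beyond the scatter)). Nothing available explains this jump. Going by these compounds, whether a pentyl or hexyl chain on the amine nitrogen would climb further or fall back remains open.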